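Phenoxy variation on the shared core, compound 2 to compound 3

A few compounds are considered here, and "the series" means these few. Any claim that something is new, unique, unknown or untested is made for them only; others in the source may bear on it.

For the measured compounds named here, compound 2 `Clc1ccc(Oc2ccc3c(NCCCNCc4ccco4)ccnc3c2)cc1` gives 317 10^-6 cm/s in an ADME assay for permeability, using PAMPA, with a stated time of 30 min, at pH 7.4 (a higher number here means that the compound crosses the layer faster, a lower number that the compound crosses the layer more slowly), the highest of the two numbers measured so far; its nearest neighbour is compound 1 `Fc1ccc(Cc2ccc3c(NCCCNCc4ccco4)ccnc3c2)c(Cl)c1`, which in this assay gives 23 10^-6 cm/s. Going by the values given here, the single measured step, a 14-fold higher number from compound 1 to compound 2 (1.14 log units; beyond the scatter), exchanges the whole substituent on the aromatic carbon and therefore lies beyond the scatter. Compound 3 `CN(C)c1cccc(Oc2ccc3c(NCCCNCc4ccco4)ccnc3c2)c1` differs from compound 2 in one place: 3-(dimethylamino)phenyl in place of 4-chlorophenyl on an oxygen on an aromatic ring. Among the compounds with values here, no measured step varies the ring on the oxygen while keeping the ether link, so the one step at hand bears only loosely on this change, and its large size cannot be carried over directly. For compound 3 a step downward of moderate size from compound 2, a 1.8-fold lower number from compound 2 to compound 3 (0.25 log units; within the scatter), is expected in this assay. The estimate for compound 3 in this assay is 180 10^-6 cm/s, with a range from 70 10^-6 cm/s to 400 10^-6 cm/s.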

Compound 3, apparent permeability in the ADME assay: 317 10^-6 cm/s
For compound 3 the middle estimate is 1.8-fold (0.25 log units) below the measured one; measured number inside the range.
By their numbers in the ADME assay, from the lowest: compound 1; then compounds 2 and 3 (each within the scatter of the next).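

In the ADME assay, 3-(dimethylamino)phenyl in place of 4-chlorophenyl on the oxygen gives no change at the digits printed from compound 2 to compound 3 (within the scatter), so the two aryl groups are not separated at this position, although the entering group is larger by the heavy-atom count and brings a hydrogen-bond acceptor. In the ADME assay the large step from the 2-chloro-4-fluorobenzyl compound recurs with the new phenoxy group, as a 14-fold higher number from compound 1 to compound 3 (1.14 log units; beyond the scatter). In a physicochemical assay for acid dissociation, compound 2 gives 9.28 and compound 3 gives 9.28, so neither read-out separates this pair. Nothing at hand explains this equality.

Open, from the compounds shown here alone, is whether the flat result extends to a carboxylic acid or a morpholine on the phenyl ring. Also open, going by these compounds, is whether the large step from compound 1 holds with substituents other than these two phenoxy groups.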